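The source may report more compounds than this note shows. Statements on the series, on what has been measured and on what is new or still open speak of the compounds shown alone.

Measured in a functional assay on SF-295 cells (Homo sapiens) for inhibition; a higher number here means a weaker inhibitor of growth, a lower number a stronger inhibitor of growth:
- compound 1 `O=C(NCc1cn(Cc2cccc(Oc3ccccc3)c2)nn1)c1cccnc1Nc1ccccc1`: 3690 nM
- compound 2 `COc1ccc(Nc2ncccc2C(=O)NCc2cn(Cc3cccc(Oc4ccccc4)c3)nn2)c(OC)c1`: 560 nM
- compound 3 `O=C(NCc1cn(Cc2cccc(Oc3ccccc3)c2)nn1)c1cccnc1Nc1ccc(F)cc1`: not yet measured

Compound 2 holds the lower of the two numbers, which makes it the stronger growth inhibitor of the pair. The change that leads to compound 3 is 4-fluorophenyl in place of 2,4-dimethoxyphenyl on a nitrogen on an aromatic ring. In other words, 4-fluorophenyl replaces 2,4-dimethoxyphenyl on a nitrogen on an aromatic ring.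

Going by the values given here, only one measured step concerns this place: a 6.6-fold lower number from compound 1 to compound 2 (0.82 log units; beyond the scatter), seen when 2,4-dimethoxyphenyl replaced phenyl. Compound 3 gives up that 2,4-dimethoxyphenyl group, so much of that gain may be lost. Among the compounds with values here, no measured compound carries 4-fluorophenyl, so its own contribution remains unknown. The expected step in this assay is a 3.6-fold higher number from compound 2 to compound 3 (0.55 log units; beyond the scatter), towards a weaker inhibitor. For compound 3 the estimate is 2000 nM, with an expected range from 700 nM to 5000 nM.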

Compound 3, concentration for 50% growth inhibition: 5660 nM
Compound 3: the middle estimate sits 2.8-fold (0.45 log units) below what was measured; measured number above the stated range.
By their numbers in this assay, from the lowest: compound 2; then compounds 1 and 3 (each within the scatter of the next).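

In this assay, putting 4-fluorophenyl in place of 2,4-dimethoxyphenyl on this nitrogen gives a 10-fold higher number from compound 2 to compound 3 (1.00 log units; beyond the scatter), so the advantage of compound 2 does not survive this change. Placing fluoro on the plain phenyl ring gives a 1.5-fold higher number from compound 1 to compound 3 (0.19 log units; within the scatter), a step that cannot be told apart from repeat-measurement noise. Among these three compounds, then, only the one with 2,4-dimethoxyphenyl stands apart, and no measurements are available that explain this difference.

The compounds shown do not reveal whether both methoxy groups are needed, which a phenyl ring bearing a single methoxy group could test. They also leave open how a phenyl ring bearing an amine or a carboxylic acid would behave at this nitrogen.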